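Swapping the benzyl amide for a pentyl chain

This account rests on a few compounds, and the source may have more. Where it says the series, first, only, none or still open, it means among the compounds named here.

Three compounds share one core, differing only in the amide substituent and the aryl group. Compound 1 `C=CC1=C(C(=O)NCc2ccccc2)C(c2ccc(Cl)c(Cl)c2)OC1` carries a benzyl group on the amide nitrogen. Compound 2 `C=CC1=C(C(=O)NC2CCCCC2)C(c2ccc(F)cc2)OC1` and compound 3 `C=CC1=C(C(=O)NCC(C)C)C(c2ccc(OC)cc2)OC1` carry cyclohexyl and isobutyl groups instead. In a functional assay on HeLa cells (Homo sapiens) for cytotoxicity, read by MTT assay, with a stated time of 24 h (a lower number here means a stronger inhibitor, a higher number a weaker inhibitor), compound 1 reaches only the upper limit of the assay, giving > 100000 nM, a limit rather than a number. In this assay compound 2 likewise stops at a limit, > 100000 nM. In this assay compound 3 also stops at a limit, > 100000 nM. All three therefore stand together at the same boundary, (the limit of > 100000 nM in this assay, at which 3 of the 3 values shown sit), and no ranking among them can be read from these figures.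

Compound 4 `C=CC1=C(C(=O)NCCCCC)C(c2ccc(Cl)c(Cl)c2)OC1` is the next structure to be tested. It differs from compound 1 by butyl in place of phenyl on a saturated chain carbon bound to an amide-type nitrogen. Since every measured analogue sits at the limit, the expected step that the limit leaves unreadable from compound 1 to compound 4 in this assay is none beyond the scatter. Compound 4 is accordingly estimated to give 150000 nM, with a plausible range from 50000 nM to 500000 nM, most likely reported again only as a limit.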

Compound 4, half-maximal inhibitory concentration: > 100000 nM
Compound 4 ended at the assay's limit (the forecaster's own chance of this, stated with the estimate: 85%); the middle value is on the limit's open side.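

No step can be read from compound 1 to compound 4 in this assay, because both values are limits rather than numbers: the limit of > 100000 nM in this assay, at which 4 of the 4 values shown sit.

The compounds shown leave open how the amide substituent or the aryl group affects cytotoxicity, as none gives a value that can be ranked.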